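Thiazolyl for dimethylpyrimidinyl on a sulfonamide nitrogen

The source may report more compounds than this note shows. Statements on the series, on what has been measured and on what is new or still open speak of the compounds shown alone.

Measured compounds:
compound 1 `Cc1nccn1CCOC(=O)[C@@H](C)c1ccc(-c2ccccc2)c(F)c1`, 5.92 h
compound 2 `Cc1cc(C)nc(N(COC(=O)c2ccccc2)S(=O)(=O)c2ccc(N)cc2)n1`, 0.69 h
compound 3 `COc1ccc2cc([C@H](C)C(=O)OCN(C)C(=O)c3ccccc3)ccc2c1`, 1.2 h

In an ADME assay on a cell-free system (plasma, Homo sapiens) for metabolic stability (on this read-out higher numbers stand for a longer-lived compound and lower numbers for a shorter-lived compound), compound 2 gives 0.69 h and sits at the low end of the three numbers. Its gap to compound 3, which gives 1.2 h in this assay, lies within the usual scatter, so the two cannot be told apart; compound 1, with 5.92 h, stands clearly beyond that scatter. Compound 4 `Nc1ccc(S(=O)(=O)N(COC(=O)c2ccccc2)c2cncs2)cc1` has not yet been measured. It differs from compound 2 in one place: 1,3-thiazol-5-yl in place of 4,6-dimethylpyrimidin-2-yl on a sulfonamide nitrogen. Going by the values given here, no measured pair shows the effect of this exchange, so the step is expected to stay within the scatter, with no clear direction. Compound 4 is therefore estimated at 0.7 h, within 0.3 h to 1.6 h, a step of a 1.0-fold higher number from compound 2 to compound 4 (0.01 log units; within the scatter) in this assay.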

Compound 4, half-life: 0.002 h
Estimate against measurement, compound 4: 350-fold (2.54 log units) above; measured number outside the range, below it.
By their numbers in this assay, from the lowest: compound 4; then compounds 2 and 3 (each within the scatter of the next); then compound 1.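

The group on the sulfonamide nitrogen decides much of the outcome in this assay: with the rest of the molecule unchanged, 1,3-thiazol-5-yl in place of 4,6-dimethylpyrimidin-2-yl gives a 350-fold lower number from compound 2 to compound 4 (2.54 log units; beyond the scatter) and so lies far beyond the scatter. Going by these compounds alone, the earlier compounds included no pair differing in one place, so this is the first sign that a single change here can move the half-life so far. Nothing measured here explains the size of this step. As far as these compounds go, whether a phenyl or a pyridin-2-yl group on the same nitrogen would stay near compound 2 or fall towards compound 4 remains open. So does whether 1,3-thiazol-2-yl would give a similar step.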